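Chloro to (trifluoromethyl)sulfanyl on compound 1

The source may hold more compounds than are shown below. What is called first, only, known or untested is meant among the compounds shown, and "the series" means these compounds.

Measured so far in a functional assay on MCF7 cells (Homo sapiens) for inhibition, read by MTT assay, with a stated time of 72 h; a lower number here means a stronger inhibitor, a higher number a weaker inhibitor
- compound 1 `C=C(Br)C(=O)Nc1cccc(/C=C/C(=O)Nc2ccc(Cl)cc2)c1` gives 11000 nM
- compound 2 `C=C(Br)C(=O)Nc1cccc(/C=C/C(=O)NCc2ccc(C)cc2)c1` gives 2200 nM

Compound 1 has the higher number of the two, making it the weaker inhibitor of the pair. Compound 3 (`C=C(Br)C(=O)Nc1cccc(/C=C/C(=O)Nc2ccc(SC(F)(F)F)cc2)c1`) keeps the core of compound 1 but carries (trifluoromethyl)sulfanyl in place of chloro on an aromatic carbon. Among the measured compounds shown here, the only measured step (a 5.0-fold lower number from compound 1 to compound 2 (0.70 log units; beyond the scatter)) is modest and beyond the scatter, but it replaces 4-chlorophenyl with 4-methylbenzyl, so it bears on this change only loosely. A smaller drop is therefore expected in this assay, an estimated 2.2-fold lower number from compound 1 to compound 3 (0.34 log units; beyond the scatter) as the expected step. For compound 3 the estimated value is 5000 nM (expected range 1800 nM to 14000 nM).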

Compound 3, half-maximal inhibitory concentration: 30100 nM
Beside the measured number, compound 3's estimate is 6.0-fold (0.78 log units) below it; the whole stated range lies below it.
By their numbers in this assay, from the lowest: compound 2; then compound 1; then compound 3.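

In this assay, putting (trifluoromethyl)sulfanyl in place of chloro, para to a large group, gives a 2.7-fold higher number from compound 1 to compound 3 (0.44 log units; beyond the scatter) and so a weaker inhibitor. The earlier step exchanged the whole 4-chlorophenyl for 4-methylbenzyl, whereas this one shows that the aromatic substituent alone can shift the number beyond the scatter. Nothing available explains why the number moves this way.

As far as these compounds go, it remains open whether a methoxy group or an amine at this position would give a lower number than chloro. Whether the same swap would act alike on compound 2 is also unknown.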